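The compounds below may be only part of what the source reports. "The series", "measured", "known", "first", "only" and "open" are said of these compounds alone.

Compound 1 `O=C(Nc1cccc(Cl)c1)Nc1nnc(Sc2ncnc3scc(-c4ccncc4)c23)s1` and compound 2 `Cc1ccc(NC(=O)Nc2nnc(Sc3ncnc4scc(-c5ccncc5)c34)s2)cc1Cl` share one core and differ only in a methyl group on the aromatic ring at the end of the urea. In a functional assay on T47D cells (Homo sapiens) for antiproliferative activity, read by MTT assay, with a stated time of 48 h (on this read-out higher numbers stand for weaker inhibition and lower numbers for stronger inhibition), compound 1 gives 43900 nM, the highest of the two numbers in hand, and compound 2 gives 34800 nM. The step of a 1.3-fold lower number from compound 1 to compound 2 (0.10 log units; within the scatter) is too small to count as a real difference. Compound 3 `O=C(Nc1cccc(F)c1)Nc1nnc(Sc2ncnc3scc(-c4ccncc4)c23)s1` is not yet measured; it keeps the same core and urea and changes only the halogen on that ring: fluoro in place of chloro on an aromatic carbon. Going by the values given here, no measured pair here swaps one halogen for another, so the only guidance is that the single change seen on this ring, the methyl in the step from compound 1 to compound 2, left this assay essentially unchanged. A swap of chloro for fluoro at the same position is therefore expected to do little as well, with the number for compound 3 staying close to that of compound 1. The expected step is a 1.1-fold higher number from compound 1 to compound 3 (0.06 log units; within the scatter). Compound 3 is estimated to give 50000 nM in this assay, most likely between 20000 nM and 120000 nM.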

Compound 3, half-maximal inhibitory concentration: 16700 nM
Beside the measured number, compound 3's estimate is 3.0-fold (0.48 log units) above it; measured number outside the range, below it.
By their numbers in this assay, from the lowest: compound 3; then compounds 2 and 1 (each within the scatter of the next).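

In this assay, this carbon of the ring at the end of the urea proves more sensitive than the earlier pair suggested. Adding a methyl gave only a 1.3-fold lower number from compound 1 to compound 2 (0.10 log units; within the scatter), whereas the swap of one halogen for another, fluoro in place of chloro on an aromatic carbon meta to a large group, gives a 2.6-fold lower number from compound 1 to compound 3 (0.42 log units; beyond the scatter), a modest change but a real one. Compound 3 also stands apart from the methyl-bearing compound, with a 2.1-fold lower number from compound 2 to compound 3 (0.32 log units; beyond the scatter), so it is the most potent of the three here, though that step changes both the halogen and the methyl and cannot be credited to either alone.

Going by these compounds, a single halogen swap gives no trend, so it remains open whether an unsubstituted phenyl, or a methoxy, trifluoromethyl or amino group at this carbon, would lower the number further, and whether fluoro would do the same elsewhere on the ring. Nothing in the available data explains why fluoro gives the lower number here.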